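The source may report more compounds than this note shows. Statements on the series, on what has been measured and on what is new or still open speak of the compounds shown alone.

Within the data shown here, in a physicochemical assay for lipophilicity, read by HPLC, at pH 7.5 (on this read-out lower numbers stand for lower lipophilicity and higher numbers for higher lipophilicity), compound 1 (`CC[C@@H](Nc1c(C#N)c(-c2ccc(-c3ccncc3C)cc2)nc2cnccc12)C(N)=O`) reads 2 and compound 2 (`CC[C@@H](Nc1c(C#N)c(-c2ccc(-c3cccnc3C)cc2)nc2cnccc12)C(N)=O`) reads 1.9 so compound 2 stands within the scatter of compound 1, the only other number so far. Among the measured compounds shown here, the one measured step is a number 0.10 log units lower from compound 1 to compound 2 (within the scatter) for 2-methylpyridin-3-yl in place of 3-methylpyridin-4-yl on an aromatic carbon. Compound 3 (`CC[C@@H](Nc1c(C#N)c(-c2ccc(-c3ccc(Cl)cc3)cc2)nc2cnccc12)C(N)=O`) carries 4-chlorophenyl in place of 2-methylpyridin-3-yl on an aromatic carbon, para to a large group (4-chlorophenyl in place of 2-methylpyridin-3-yl on an aromatic carbon). The measured step has a ring with a hetero atom on both sides, so it gives no direct size for a change to a ring of carbon only. The step expected in this assay rests on the structural change alone and is upward, beyond the scatter: the estimate is a number 1.20 log units higher from compound 2 to compound 3 (beyond the scatter) on this read-out. For compound 3 the estimated value is 3.1 (expected range 2.5 to 3.7).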

Compound 3, distribution coefficient: 3.1
Compound 3: middle estimate and measured number agree at the digits printed, within the range that was stated.
By their numbers in this assay, from the lowest: compounds 2 and 1 (each within the scatter of the next); then compound 3.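

In this assay, among these compounds, the place on an aromatic carbon para to a large group proves responsive to the ring that sits there: the read-out gives a number 1.20 log units higher from compound 2 to compound 3 (beyond the scatter) and a number 1.10 log units higher from compound 1 to compound 3 (beyond the scatter), whereas the only earlier step, between two methylpyridine groups, stayed within the scatter. In the step to compound 3, a six-membered aromatic ring with 1 hetero atom and 1 hydrogen-bond acceptor gives way to a six-membered aromatic ring of carbon only with 0 hydrogen-bond acceptors, while both groups have 7 heavy atoms. No measured data account for the size of these steps.

Going by these compounds, whether the step follows the loss of the ring nitrogen or the arrival of the chlorine stays open, and a plain phenyl or a 4-methylphenyl would separate the two. Also open, on these data alone, is how the read-out responds to an amine or a carboxylic acid on this ring.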